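A Longer Chain on Sulfur: Compound 3 to Compound 4

A few compounds are considered here, and "the series" means these few. Any claim that something is new, unique, unknown or untested is made for them only; others in the source may bear on it.

Measured in a functional assay on MCF7 cells (Homo sapiens) for cytotoxicity, read by MTT assay, with a stated time of 72 h; a higher number here means a weaker inhibitor, a lower number a stronger inhibitor:
Compound 1 (`O=C(CSC(=S)N[C@H]1CCOC1=O)Nc1ccc(Cl)cc1Cl`) gives 29200 nM.
Compound 2 (`COc1ccc(NC(=O)CSC(=S)N[C@H]2CCOC2=O)cc1`) gives > 128000 nM, which is a limit of the assay and not a number.
Compound 3 (`CSC(=S)N[C@H]1CCOC1=O`) gives > 128000 nM, again a limit of the assay and not a number.

Compound 3 therefore stands at the edge of what this assay can report, and it is not alone there, because of the limit of > 128000 nM in this assay, at which 2 of the 3 values shown sit. Only compound 1 has a number at all, and that number describes a weak inhibitor.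

Compound 4 (`CCCCCCSC(=S)N[C@H]1CCOC1=O`) is compound 3 with one change: pentyl in place of hydrogen on a saturated chain carbon bound to a sulfur. Among the measured compounds shown here, no measured pair here shows what such a change does, so the expectation rests on compound 3 alone and on the shared core.

The step from compound 3 to compound 4 is expected to be an at least 1.4-fold lower number from compound 3 to compound 4 (0.15 log units; that floor lies within the scatter), toward a somewhat stronger inhibitor but not far beyond the scatter. For compound 4 the estimated value in this assay is 90000 nM, with a likely range from 30000 nM to 200000 nM, and a real chance that only a limit is reported again.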

Compound 4, half-maximal inhibitory concentration: > 128000 nM
Compound 4: no number, only a limit; the forecaster's own chance of this, stated with the estimate: 45%; middle value at least 1.4-fold (0.15 log units) from the limit.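

Compound 3 and compound 4 each give only a limit in this assay, not a number, and the step between them cannot be read. The compounds shown leave open whether pentyl in place of hydrogen on a saturated chain carbon bound to a sulfur changes potency at all.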